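This account rests on a few compounds, and the source may have more. Where it says the series, first, only, none or still open, it means among the compounds named here.

Compounds measured so far:

- compound 1, `Cc1cc(=O)n(-c2cccc(F)c2)nc1C(=O)Nc1ccc(Oc2ncnc3[nH]ccc23)cc1`: 14600 nM
- compound 2, `Cc1cc(=O)n(-c2ccc(F)cc2)nc1C(=O)Nc1ccc(Oc2ncnc3[nH]ccc23)c(F)c1`: 17300 nM
- compound 3, `Cc1cc(=O)n(-c2cccc(F)c2)nc1C(=O)Nc1ccc(Oc2ncnc3[nH]ccc23)c(F)c1`: 6680 nM

All three were tested in a functional assay on PC-3 cells (Homo sapiens) for cytotoxicity, read by MTT assay, with a stated time of 72 h; a lower number here means a stronger inhibitor, a higher number a weaker inhibitor. Compound 3 gives the lowest number of the three, which makes it the strongest inhibitor in this small set; compound 1 is its nearest neighbour, and compound 2 the furthest. Two single changes lead to compound 3. From compound 1 the step is a 2.2-fold lower number from compound 1 to compound 3 (0.34 log units; beyond the scatter), a modest gain. From compound 2 the step is a 2.6-fold lower number from compound 2 to compound 3 (0.41 log units; beyond the scatter), also modest, and this one changes the aryl group on the aromatic nitrogen, the same place that is altered next.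

Compound 4, `Cc1cc(=O)n(-c2ccccc2OC(F)(F)F)nc1C(=O)Nc1ccc(Oc2ncnc3[nH]ccc23)c(F)c1`, differs from compound 3 in one place: 2-(trifluoromethoxy)phenyl in place of 3-fluorophenyl on an aromatic nitrogen. The entering group is larger than the one it replaces and carries a trifluoromethoxy group. Among the measured compounds shown here, no measured pair shows this exact exchange, so the expectation rests only on the step from compound 2 to compound 3, which shows that moving a substituent around this aryl ring shifts the number modestly. A shift of similar size, in either direction, is therefore expected, with no firm ground for choosing one; the estimate stays near compound 3, a 1.2-fold higher number from compound 3 to compound 4 (0.08 log units; within the scatter). Compound 4 is estimated at 8000 nM, within a range from 2500 nM to 25000 nM.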

Compound 4, half-maximal inhibitory concentration: > 60000 nM
Compound 4 gave a limit, no number; the forecaster's own chance of this, stated with the estimate: 10%; at least 7.5-fold (0.87 log units) between middle value and limit.
By their numbers in this assay, from the lowest: compound 3; then compounds 1 and 2 (each within the scatter of the next). At a limit, above all of these: compound 4.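

In this assay, compound 4 gives a limit and not a number: the limit of > 60000 nM in this assay, at which 1 of the 4 values shown sits.

Until now, changing the aryl group on this aromatic nitrogen had only nudged the result, but placing 2-(trifluoromethoxy)phenyl there brings a far larger loss of inhibition, with an at least 8.9-fold higher number from compound 3 to compound 4 (0.95 log units; beyond the scatter) and an at least 3.4-fold higher number from compound 2 to compound 4 (0.54 log units; beyond the scatter). The position is therefore not indifferent to what it carries: the two fluorophenyl groups in compound 2 and compound 3 keep a measurable number in this assay, whereas the larger entering group, with its trifluoromethoxy substituent, does not.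

This single exchange alters both the substituent and where it sits on the aryl ring, so the compounds shown cannot say which of the two matters, and a 2-fluorophenyl or a 3-(trifluoromethoxy)phenyl group on the same nitrogen would help to separate them. They also leave open how this position would respond to an aryl ring bearing an amine or a carboxylic acid, or to a plain unsubstituted phenyl group.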